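Urea to amide swap at the anilide of compound 2

A few compounds are considered here, and "the series" means these few. Any claim that something is new, unique, unknown or untested is made for them only; others in the source may bear on it.

Compound 2 `COc1cc(-c2nn(-c3cccc(NC(=O)Nc4ccc(Cl)c(Cl)c4)c3)cc2-c2ccncc2)ccc1Cl` is assessed in a functional assay on CAKI-1 cells (Homo sapiens) for inhibition, read by sulforhodamine B assay, with a stated time of 48 h; on this read-out lower numbers stand for higher toxicity in this test and higher numbers for lower toxicity in this test. Compound 2 reaches only the limit of the test there, > 50000 nM. Compound 1 `COc1cc(-c2nn(-c3cccc(NC(=O)Nc4cc(C(F)(F)F)cc(C(F)(F)F)c4)c3)cc2-c2ccncc2)ccc1Cl` gives 49300 nM in this assay. For compound 3 `O=C(Nc1cccc(-n2cc(-c3ccncc3)c(-c3ccc(Cl)c(O)c3)n2)c1)Nc1ccc(Cl)c(Cl)c1` this assay again returns only a limit, > 32500 nM. Among the measured compounds shown here, the one single-point change among the measured compounds, a step that the two limits leave unreadable from compound 2 to compound 3, cannot be sized because the limit of > 50000 nM in this assay, at which 1 of the 3 values shown sits, and the limit of > 32500 nM in this assay, at which 1 of the 3 values shown sits, cap both of its ends. On the numbers shown compound 2 therefore stands as a limit, beside a second limit for compound 3 and a plain number for compound 1 that lies close to the top of the tested range.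

Compound 4 `COc1cc(-c2nn(-c3cccc(NC(=O)c4ccc(Cl)c(C(F)(F)F)c4)c3)cc2-c2ccncc2)ccc1Cl` differs from compound 2 by 4-chloro-3-(trifluoromethyl)phenyl in place of (3,4-dichlorophenyl)amino on a carbonyl carbon. For the measured compounds named here, no measured step touches that part of the molecule; the only measured step runs from compound 2 to compound 3 and concerns the methyl on the oxygen, and it is unreadable. Nothing in the measured set points to a step beyond scatter in this assay for this change. Compound 4 is therefore expected to give about 50000 nM in this assay, within 25000 nM to 100000 nM, and a further limit rather than a number is a likely outcome. The step of a number no higher from compound 2 to compound 4 (the limit leaves the size open) that this estimate implies is expected to stay within scatter.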

Compound 4, concentration lethal to 50% of the cells: > 32500 nM
Compound 4: only a limit was reported; the forecaster's own chance of this, stated with the estimate: 60%; the middle value does not contradict the limit.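

In this assay compound 4 returns only a limit, > 32500 nM. Among the compounds shown here, compound 2 also stands as a limit there, so no step from compound 2 to compound 4 can be read. The compounds shown leave open whether 4-chloro-3-(trifluoromethyl)phenyl in place of (3,4-dichlorophenyl)amino on the carbonyl carbon changes the lethal concentration at all in this assay.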